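The source may hold more compounds than are shown below. What is called first, only, known or untested is meant among the compounds shown, and "the series" means these compounds.

Compound 2 `COc1cc(/C=C/C(=O)Nc2ccccc2)ccc1OCCCCN1CCCCC1` is one of two compounds examined in a physicochemical assay for lipophilicity, using the shake flask method, measured as octanol-water partition, at pH 7.4 (a higher number here means a more lipophilic compound, a lower number a more polar compound), in which compound 2 gives 1.61. Its companion, compound 1 `COc1cc(/C=C/C(=O)Nc2ccccc2)ccc1OCCCN1CCCC1`, gives 1.57 in this assay; the step of a number 0.04 log units higher from compound 1 to compound 2 (within the scatter) is too small to separate the two, so compound 2 cannot be told apart from compound 1 on these numbers. Compound 3 `CCN(CC)CCCCCCCCCCOc1ccc(/C=C/C(=O)Nc2ccccc2)cc1OC` has not been measured in this assay. It differs from compound 2 in one place: 6-(diethylamino)hexyl in place of piperidin-1-yl on a saturated chain carbon, four bonds along the chain from an oxygen on an aromatic ring. Among the measured compounds shown here, the only measured step, a number 0.04 log units higher from compound 1 to compound 2 (within the scatter), exchanged one saturated amine ring for another with one added chain carbon and left the partition coefficient unchanged within the scatter, so it says little about a change of this size. The change to compound 3 adds far more saturated carbon than that step did, and in this assay such a change is expected to raise the partition coefficient well beyond the scatter. Compound 3 is therefore estimated at 3.7, within a range of 2.9 to 4.5, an expected step of a number 2.09 log units higher from compound 2 to compound 3 (beyond the scatter).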

Compound 3, partition coefficient: 1.83
Beside the measured number, compound 3's estimate is 1.87 log units above it; measured number below the stated range.
By their numbers in this assay, from the lowest: compounds 1, 2 and 3 (each within the scatter of the next).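

Among the compounds shown here, at this position, on a saturated chain carbon, four bonds along the chain from an oxygen on an aromatic ring, the earlier compounds showed only one saturated amine ring exchanged for another, whereas this change replaces piperidin-1-yl, with 6 heavy atoms and one ring, by 6-(diethylamino)hexyl, with 11 heavy atoms and no ring. Even so, this assay gives a number 0.22 log units higher from compound 2 to compound 3 (within the scatter) and so does not separate the two compounds, which shows that a change of this size at this position can leave the read-out within the scatter. Nothing shown here accounts for this result.

The compounds shown leave open whether a group of another kind at the end of this chain, such as a carboxylic acid, a hydroxyl or a morpholine ring, would move the partition coefficient beyond the scatter. They also leave open whether a plain decyl chain with no amine, or a still longer chain ending in diethylamino, would give a step that could be told apart from these.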